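Swapping methoxy for hydroxy in a cytotoxicity series

The compounds below may be only part of what the source reports. "The series", "measured", "known", "first", "only" and "open" are said of these compounds alone.

Of the compounds shown here, three sharing one core have been tested in a functional assay on SF-539 cells (Homo sapiens) for cytotoxicity, read by sulforhodamine B assay, with a stated time of 48 h, tested at 0.01 uM; a lower number here means a stronger effect, a higher number a weaker effect of the compound at the concentration tested. Compound 1 `COc1cc(C)cc(-c2c(-c3ccnc(-c4ccc(C(C)=O)cc4)c3)cnn2CC#N)c1` gives 98%, compound 2 `Cc1cc(O)cc(-c2nn(CC#N)cc2-c2ccnc(-c3ccc(Oc4ccccc4)cc3)c2)c1` gives 88%, and compound 3 `COc1cc(C)cc(-c2nn(CC#N)cc2-c2ccnc(-c3ccc(N(C)C)cc3)c2)c1` gives 107%. Compound 3 thus stands highest of the three, with compound 1 within the scatter of it and compound 2 beyond it. Compound 4 `Cc1cc(O)cc(-c2nn(CC#N)cc2-c2ccnc(-c3ccc(N(C)C)cc3)c2)c1` differs from compound 3 in one place: hydrogen in place of methyl on an oxygen on an aromatic ring. Among the measured compounds shown here, no measured pair shows this change alone, so the step is guessed from what the numbers show. Compound 2, which carries the hydroxy group, gives 88%, so a modest downward step is expected for compound 4 in this assay, of about a number 10 percentage points lower from compound 3 to compound 4 (within the scatter). Compound 4 is estimated at 97%, in the range 84% to 110%.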

Compound 4, a percentage reported as activity, at one concentration (the size of the read-out at that concentration, not a potency): 92%
The estimate for compound 4 lay 5 percentage points above the measured number; measured number inside the range.
By their numbers in this assay, from the lowest: compounds 2, 4, 1 and 3 (each within the scatter of the next, the first and the last beyond it).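

In this assay, the change from methoxy to hydroxy now has a direct reading, with everything else in the molecule the same: it gives a number 15 percentage points lower from compound 3 to compound 4 (beyond the scatter) and counts as a modest step. With the hydroxy group kept, dimethylamino in place of phenoxy gives a number 4 percentage points higher from compound 2 to compound 4 (within the scatter) and so does not separate the two compounds. Nothing available here explains either step. As far as these compounds go, whether the methoxy step holds with other groups on the shared core remains open, as does how an amine or an ethoxy group would read at this place.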